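Removing the methoxy group from compound 3

This account rests on a few compounds, and the source may have more. Where it says the series, first, only, none or still open, it means among the compounds named here.

In a functional assay on A549 cells (Homo sapiens) for antiproliferative activity, read by MTT assay, with a stated time of 72 h (a higher number here means a weaker inhibitor, a lower number a stronger inhibitor), compound 3 (`COc1ccc(/C=C/C(=O)/C=C/c2nc(C)c(C)nc2C)cc1`) gives 3500 nM. It stands in a tight group, with compound 1 (`Cc1nc(C)c(/C=C/C(=O)/C=C/c2ccc(O)cc2)nc1C`) at 4010 nM and compound 2 (`COc1ccccc1/C=C/C(=O)/C=C/c1nc(C)c(C)nc1C`) at 3200 nM, all three within the usual scatter of one another. Compound 4 (`Cc1nc(C)c(/C=C/C(=O)/C=C/c2ccccc2)nc1C`) has hydrogen in place of methoxy on an aromatic carbon, para to a large group: hydrogen in place of methoxy on an aromatic carbon. For the measured compounds named here, the only measured step involving that oxygen is a 1.1-fold lower number from compound 1 to compound 3 (0.06 log units; within the scatter). Going by the values given here, no measured compound lacks the oxygen, so this is a limited guide. On that evidence, no step beyond the scatter is expected in this assay. The expected step is a 1.0-fold higher number from compound 3 to compound 4 (0.01 log units; within the scatter). Compound 4 is estimated at 3600 nM, with an expected range of 1800 nM to 7000 nM.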

Compound 4, half-maximal inhibitory concentration: 12300 nM
Compound 4: the middle estimate sits 3.4-fold (0.53 log units) below what was measured; measured number above the stated range.
By their numbers in this assay, from the lowest: compounds 2, 3 and 1 (each within the scatter of the next); then compound 4.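

In this assay the oxygen on this ring carbon proves to matter: a 3.5-fold higher number from compound 3 to compound 4 (0.55 log units; beyond the scatter) and a 3.1-fold higher number from compound 1 to compound 4 (0.49 log units; beyond the scatter) show that removing it weakens the compound, whether it is present as methoxy or as hydroxy, although exchanging one of these groups for the other made no change beyond the scatter. The step of a 3.8-fold higher number from compound 2 to compound 4 (0.58 log units; beyond the scatter) is of similar size, with the methoxy of compound 2 at a different ring carbon. Nothing available here explains this loss. On these data alone, whether an amine or a fluorine at this ring carbon would behave like methoxy or like hydrogen remains open. So does whether a longer chain on the oxygen would keep the stronger numbers.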